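The compounds below may be only part of what the source reports. "The series", "measured", "known", "first", "only" and "open" are said of these compounds alone.

In a physicochemical assay for lipophilicity, using the shake flask method, in phosphate buffer, measured as octanol-water partition, with a stated time of 24 h, at pH 7.4, tested at 100 uM (a lower number here means a more polar compound, a higher number a more lipophilic compound), the entry for compound 1 (`COc1cc(C)c(-c2cccc(COc3ccc4c(c3)SCC4CC(=O)O)c2)c(C)c1`) reads "not determined" (no result reported), and the entry for compound 2 (`COc1cc(C)c(-c2cccc(COc3ccc4c(c3)C(O)CC4CC(=O)O)c2)c(C)c1`) reads "not determined" (no result reported). Going by the values given here, compound 3 (`O=C(O)CS(=O)(=O)c1ccc(OCc2cccc(-c3ccccc3Cl)c2)cc1`) gives 2.47, the only number available, so it cannot be ranked against the others. Compound 4 (`CCOc1ccc(-c2cccc(COc3ccc(S(=O)(=O)CC(=O)O)cc3)c2)c(Cl)c1`) differs from compound 3 in one place: ethoxy in place of hydrogen on an aromatic carbon. Among the compounds with values here, no measured pair here shows the effect of such a change in this assay, so the expectation rests on the structural change alone. The estimated step is a moderate rise beyond the usual scatter, a number 0.43 log units higher from compound 3 to compound 4 (beyond the scatter). For compound 4, the expected value is 2.9, with an estimated range from 2.55 to 3.3.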

Compound 4, distribution coefficient: 3.12
For compound 4 the middle estimate is 0.22 log units below the measured one, within the range that was stated.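

In this assay, going by these compounds alone, the change from 2-chlorophenyl to 2-chloro-4-ethoxyphenyl gives a number 0.65 log units higher from compound 3 to compound 4 (beyond the scatter) and is the first measured step at this position. It shows that the reading at this aromatic carbon, para to a large group and meta to the chloro group, moves with ethoxy in place of hydrogen. Nothing shown bears on the reason for this step. Going by these compounds, whether a hydroxyl group, an amine or a longer propoxy chain on the same carbon would move the reading in the same direction remains open. So does whether ethoxy would act alike without the chloro group.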